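Benzyl in place of pyrrolylmethyl on the amide nitrogen

This account rests on a few compounds, and the source may have more. Where it says the series, first, only, none or still open, it means among the compounds named here.

Working notes on the series. Compound 2 `CCN(Cc1cccn1C)C(=O)COc1ccc(C)cc1` carries the highest of the three numbers recorded in an assay on HEK293 cells for agonist activity at transient receptor potential cation channel subfamily M member 8 (Homo sapiens), read by fluorescence and calcium flux, with a stated time of 15 min; on this read-out lower numbers stand for an effect already at smaller amounts and higher numbers for an effect only at larger amounts of compound; in that assay compound 2 gives 21300 nM. Its nearest neighbour is compound 1 `CCN(Cc1ccoc1)C(=O)COc1ccc(C)cc1`, which in this assay gives 136 nM, and the furthest is compound 3 `Cc1ccc(OCC(=O)N(Cc2cccs2)c2c[nH]nc2C)cc1`, which in this assay gives 0.4 nM. Compound 4 `CCN(Cc1ccccc1)C(=O)COc1ccc(C)cc1` is not yet measured; its change from compound 2 is phenyl in place of 1-methyl-1H-pyrrol-2-yl on a saturated chain carbon bound to an amide-type nitrogen. Going by the values given here, one measured step bears on this position: a 160-fold higher number from compound 1 to compound 2 (2.19 log units; beyond the scatter). That step shows how much the group on the saturated chain carbon bound to the amide nitrogen can move the number, and it points to compound 4 sitting closer to compound 1 than to compound 2. Given the step of a 160-fold higher number from compound 1 to compound 2 (2.19 log units; beyond the scatter), a large step downward is expected, estimated as an 85-fold lower number from compound 2 to compound 4 (1.93 log units; beyond the scatter). For compound 4 in this assay the estimate is 250 nM, with a range from 40 nM to 2500 nM.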

Compound 4, half-maximal effective concentration: 1880 nM
Beside the measured number, compound 4's estimate is 7.5-fold (0.88 log units) below it; low and high end bracket the measured number.
By their numbers in this assay, from the lowest: compound 3; then compound 1; then compound 4; then compound 2.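

In this assay the phenyl group of compound 4 falls inside the span set by the two five-membered aromatic rings, with an 11-fold lower number from compound 2 to compound 4 (1.05 log units; beyond the scatter) and a 14-fold higher number from compound 1 to compound 4 (1.14 log units; beyond the scatter). The group on a saturated chain carbon bound to an amide-type nitrogen therefore gives three separate levels, lowest with furan-3-yl, then phenyl, and highest with 1-methyl-1H-pyrrol-2-yl, so replacing either ring with phenyl does not reproduce its number. Nothing available explains this order.

The compounds shown leave open how a cyclohexyl or pyridin-3-yl group would read at this place, and whether the pyrrole ring without its methyl group would stay at the level of compound 2. Compound 3 differs from compound 4 in more than one place, so its number cannot be assigned to a single change.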